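Amide variation on a shared pyrazole core: aryl to cyclopentylmethyl

The source may report more compounds than this note shows. Statements on the series, on what has been measured and on what is new or still open speak of the compounds shown alone.

Three amides on the same core have been measured in an assay on HEK293 cells for displacement of a labelled ligand from metabotropic glutamate receptor 5 (Rattus norvegicus); a lower number here means a stronger inhibitor, a higher number a weaker inhibitor. Compound 1 `COc1cccc(C(=O)Nc2cc(-c3ccccc3)nn2-c2ccccc2)c1` gives 1290 nM. Compound 2 `COc1cc(OC)cc(C(=O)Nc2cc(-c3ccccc3)nn2-c2ccccc2)c1` gives only a limit of the assay, > 10000 nM, with no number behind it (the limit of > 10000 nM in this assay, at which 1 of the 3 values shown sits). Compound 3 `Cc1ccc(C(=O)Nc2cc(-c3ccccc3)nn2-c2ccccc2)cc1C` gives 430 nM. Among the numbers shown compound 3 stands lowest, and the nearest number is that of compound 1, reached by a 3.0-fold lower number from compound 1 to compound 3 (0.48 log units; beyond the scatter). The step of an at least 23-fold lower number from compound 2 to compound 3 (1.36 log units; beyond the scatter) starts from a limit, as does the step of an at least 7.7-fold higher number from compound 1 to compound 2 (0.88 log units; beyond the scatter) in the other direction.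

Compound 4 `O=C(CC1CCCC1)Nc1cc(-c2ccccc2)nn1-c1ccccc1` is not yet measured. It differs from compound 3 by cyclopentylmethyl in place of 3,4-dimethylphenyl on a carbonyl carbon. Among the measured compounds shown here, every measured step changes only the substitution on the aryl group of the amide; none replaces that six-membered aromatic ring with a five-membered non-aromatic ring, so no measured step bears directly on this change. For the measured compounds named here, the one firm number on record, a 3.0-fold lower number from compound 1 to compound 3 (0.48 log units; beyond the scatter), shows that changing the group on the carbonyl carbon moves the number by a modest amount, and the change here is larger in kind than any measured one. A step beyond the scatter is therefore expected, most likely toward a higher number, giving a 5.8-fold higher number from compound 3 to compound 4 (0.76 log units; beyond the scatter) as the estimate. Compound 4 is expected to give about 2500 nM, within the range 500 nM to 10000 nM.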

Compound 4, inhibition constant: > 10000 nM
Compound 4: no number, only a limit (the forecaster's own chance of this, stated with the estimate: 30%); at least 4.0-fold (0.60 log units) between middle value and limit.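

In this assay compound 4 gives > 10000 nM as a limit of the assay, not a number. Among the compounds shown here, the step of an at least 23-fold higher number from compound 3 to compound 4 (1.36 log units; beyond the scatter) and the step of an at least 7.7-fold higher number from compound 1 to compound 4 (0.88 log units; beyond the scatter) show that cyclopentylmethyl on the carbonyl carbon, the first group without an aromatic ring, takes the compound out of the readable range, whereas the substituent changes on the aryl group in compound 1 and compound 3 both leave a number. Compound 2 goes against any simple rule that an aryl group there is enough, since it keeps one and still stops at a limit, and the step between compound 2 and compound 4 cannot be read: the limit of > 10000 nM in this assay, at which 2 of the 4 values shown sit.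

Cyclopentylmethyl differs from the aryl groups in ring size, aromaticity and the added carbon on the carbonyl together, so the compounds shown do not separate these changes, and how far compound 4 lies beyond its limit stays unknown. A benzyl group or a cyclohexyl group in the same place would bear on that question, as would a phenyl ring carrying an amine or a carboxylic acid for the range of substituents the aryl series tolerates.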